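Methylamine to fluorobenzylamine on an inactive core: one untested step

A few compounds are considered here, and "the series" means these few. Any claim that something is new, unique, unknown or untested is made for them only; others in the source may bear on it.

Compound 1 `CCOC(=O)c1cnc(NC2CCCCC2)n2nc(-c3ccco3)nc12`: > 10000 nM
Compound 2 `CNc1ncc(C(=O)O)c2nc(-c3ccco3)nn12`: > 10000 nM

In a functional assay on CHO cells for antagonist activity at adenosine receptor A2b (Homo sapiens) (a lower number here means a stronger inhibitor, a higher number a weaker inhibitor), compound 1 gives > 10000 nM, which is a limit of the assay rather than a number. Compound 2 gives > 10000 nM, also a limit. Every value shown thus sits at the edge of what the assay reports, as summed up by the limit of > 10000 nM in this assay, at which 2 of the 2 values shown sit. Compound 3 `O=C(O)c1cnc(NCc2ccc(F)cc2)n2nc(-c3ccco3)nc12` differs from compound 2 by 4-fluorophenyl in place of hydrogen on a saturated chain carbon bound to a nitrogen on an aromatic ring. Going by the values given here, no measured step supports a prediction, so only a modest improvement is expected, an at least 2.0-fold lower number from compound 2 to compound 3 (0.30 log units; that floor lies within the scatter), with a real chance of a further limit. Compound 3 is estimated at 5000 nM, between 800 nM and 30000 nM.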

Compound 3, inhibition constant: > 30000 nM
Compound 3 was reported as a limit (the forecaster's own chance of this, stated with the estimate: 50%); middle value at least 6.0-fold (0.77 log units) away from the limit.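

Compound 2 and compound 3 both give limits rather than numbers in this assay, and the step between them cannot be read. The compounds shown leave open whether any compound on the shared core gives a measurable value in this assay.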